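The compounds below may be only part of what the source reports. "The series", "measured", "known", "first", "only" and "open" are said of these compounds alone.

Compound 1 `C[C@@H](NC(=O)C1(NC(=O)c2ccc(Br)nc2)CC1)c1ccc(-n2nc(Cl)c3ccccc32)cc1F` gives 7.1 h in an in vivo ADME assay on the whole organism (strain Mongrel) for metabolic stability, with Canis familiaris (Canis lupus familiaris) as the target; a lower number here means that the compound disappears faster, a higher number that the compound lasts longer. That is numerically the higher of the two numbers shown, but the gap to its only neighbour is within the usual scatter. Compound 2 `C[C@@H](NC(=O)C1(NC(=O)c2cncc(Cl)c2)CC1)c1ccc(-n2nc(Cl)c3ccccc32)cc1F` gives 6 h in this assay, and the step of a 1.2-fold lower number from compound 1 to compound 2 (0.07 log units; within the scatter) counts as no change. Compound 3 `Cc1cncc(C(=O)NC2(C(=O)N[C@H](C)c3ccc(-n4nc(Cl)c5ccccc54)cc3F)CC2)c1` has not been measured in this assay. It differs from compound 1 by 5-methylpyridin-3-yl in place of 6-bromopyridin-3-yl on a carbonyl carbon. Going by the values given here, the only measured step that touches the same part of the molecule, the exchange of one pyridine substituent for another between compound 1 and compound 2, left the half-life where it was. Among the compounds with values here, there is no measured pair that shows what a methyl on that pyridine does, so no direction can be read from the data, and no step beyond the scatter is expected. The step from compound 1 to compound 3 is therefore estimated as a 1.1-fold lower number from compound 1 to compound 3 (0.04 log units; within the scatter). On that basis compound 3 is expected to give about 6.5 h in this assay, with a range from 3.3 h to 13 h.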

Compound 3, half-life: 2.6 h
The estimate for compound 3 lay 2.5-fold (0.40 log units) above the measured number; the whole stated range lies above it.
By their numbers in this assay, from the lowest: compound 3; then compounds 2 and 1 (each within the scatter of the next).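

In this assay the group on this pyridine proves able to move the half-life: a 2.7-fold lower number from compound 1 to compound 3 (0.44 log units; beyond the scatter) and a 2.3-fold lower number from compound 2 to compound 3 (0.36 log units; beyond the scatter) are both beyond the scatter, whereas the exchange of one halogen-bearing pyridine for the other, a 1.2-fold lower number from compound 1 to compound 2 (0.07 log units; within the scatter), counted as no change. The step from compound 2 to compound 3 is the cleaner reading, since methyl stands in place of chloro on an aromatic carbon and nothing else in the molecule differs. Among these three compounds, the two that carry a halogen on the pyridine sit within the scatter of each other and the methyl compound sits lower, with no compound going against that, although the data offer no explanation for the drop.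

The compounds shown leave open whether this lower number is particular to methyl or would also appear with a hydrogen, a methoxy group, a nitrile or a trifluoromethyl group in the same place. They also leave open how 5-bromopyridin-3-yl would stand, which would separate the choice of halogen from its place on the ring.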